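Replacing 4-bromophenyl with 4-methoxy-2-nitrophenyl in the series

The compounds below may be only part of what the source reports. "The series", "measured", "known", "first", "only" and "open" are said of these compounds alone.

In a functional assay on A549 cells (Homo sapiens) for antiproliferative activity, read by MTT assay (a lower number here means a stronger inhibitor, a higher number a weaker inhibitor), compound 1 `CC1(C)CCc2cc(C(=O)/C=C/c3ccc(OCc4cn(-c5ccc(Br)cc5)nn4)cc3)c(O)cc2O1` gives 80000 nM as its reading. Compound 2 `CC1(C)CCc2c(ccc(C(=O)/C=C/c3ccc(OCc4cn(-c5ccc(Br)cc5)nn4)cc3)c2O)O1` gives 129000 nM and so lies within the scatter of compound 1, with no order to be read between the two. For the measured compounds named here, both numbers are the only measurements available so far.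

Compound 3 `COc1ccc(-n2cc(COc3ccc(/C=C/C(=O)c4ccc5c(c4O)CCC(C)(C)O5)cc3)nn2)c([N+](=O)[O-])c1` has not yet been measured. It carries 4-methoxy-2-nitrophenyl in place of 4-bromophenyl on an aromatic nitrogen of a five-membered aromatic ring with 3 nitrogen 4-methoxy-2-nitrophenyl in place of 4-bromophenyl on an aromatic nitrogen and otherwise keeps the structure of compound 2. Going by the values given here, no measured step in this assay covers a change at this place, so the data give no direction for it.

With compound 2 at 129000 nM as the only reference point, no step beyond the scatter is expected. The estimate amounts to a 1.3-fold lower number from compound 2 to compound 3 (0.11 log units; within the scatter) and is expected to stay within the scatter, with little weight on its direction. For compound 3 the estimated value is 100000 nM with an expected range from 30000 nM to 250000 nM at the upper end.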

Compound 3, half-maximal inhibitory concentration: "not active" (no number reported)
Nothing numeric was reported for compound 3; there is nothing to compare the estimate with.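

In this assay, for the compounds shown here, compound 3 is recorded as "not active" with no number, so no step from compound 2 to compound 3 can be read. The compounds shown leave open how far, and in which direction, 4-methoxy-2-nitrophenyl in place of 4-bromophenyl moves the reading. No evidence at hand bears on this result.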